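Piperidine sulfonamide amides: maximal response working notes

A few compounds are considered here, and "the series" means these few. Any claim that something is new, unique, unknown or untested is made for them only; others in the source may bear on it.

Measured so far:
compound 1, `CCN(Cc1ccccc1)C(=O)C1CCN(S(=O)(=O)c2cccc(OC)c2)CC1`: 77%
compound 2, `CCN(Cc1ccccc1)C(=O)C1CCN(S(=O)(=O)c2ccc(C(F)(F)F)nc2)CC1`: "not determined" (no result reported)
compound 3, `CCN(Cc1ccccc1)C(=O)C1CCN(S(=O)(=O)c2ccncc2)CC1`: "not determined" (no result reported)

Among the compounds with values here, compound 1 holds the only number in the set. In a functional assay on CHO cells for positive allosteric modulation of muscarinic acetylcholine receptor M5 (Homo sapiens), read by calcium flux (a lower number here means a smaller maximal response, a higher number a larger maximal response), compound 1 gives 77%. In this assay, within the data shown here, compound 2 gives "not determined" (no result reported) and compound 3 gives "not determined" (no result reported), so no step between measured compounds can be drawn and nothing is known about where compound 1 sits relative to them.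

Compound 4, `CCN(Cc1ccccc1)C(=O)C1CCN(S(=O)(=O)c2ccc3[nH]ncc3c2)CC1`, differs from compound 1 by 1H-indazol-5-yl in place of 3-methoxyphenyl on a sulfonyl sulfur. Among the measured compounds shown here, with no measured step to lean on, the step from compound 1 to compound 4 is expected to stay within the usual scatter, a number 2 percentage points lower from compound 1 to compound 4 (within the scatter). Compound 4 is estimated at 75%, with a range from 50% to 100%.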

Compound 4, largest response reached (reported as percent of maximum), in percent of the reference or control that the assay uses: 86%
Compound 4: middle estimate off by 11 percentage points, on the low side; measured number inside the range.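

In this assay, 1H-indazol-5-yl in place of 3-methoxyphenyl on a sulfonyl sulfur gives a number 9 percentage points higher from compound 1 to compound 4 (within the scatter), so this position accepts a larger, two-ring group without a step beyond the scatter. The entering group brings a five-membered aromatic ring and a hydrogen-bond donor, and the maximal response of the two compounds cannot be told apart. Nothing at hand explains the result. Steps to compound 2 and compound 3 cannot be read. Still open, as far as these compounds go, is how the maximal response would respond to a carboxylic acid or an amine on the aromatic ring at this position.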